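The source may report more compounds than this note shows. Statements on the series, on what has been measured and on what is new or still open speak of the compounds shown alone.

In a functional assay on KBVIN cells (Homo sapiens) for antiproliferative activity, read by sulforhodamine B assay, with a stated time of 3 days (on this read-out higher numbers stand for an effect only at larger amounts of compound and lower numbers for an effect already at smaller amounts), three compounds built on one shared core have been measured. Compound 1, `CCC1=C(O)c2c(oc(-c3ccc(OC(F)(F)F)cc3)cc2=O)C(CC)(CC)C1=O`, gives 9.95 uM. Compound 2, `CCC1=C(O)c2c(oc(-c3cccc(OC(F)(F)F)c3)cc2=O)C(CC)(CC)C1=O`, gives 9.95 uM. Compound 3, `CCC1=C(O)c2c(oc(-c3ccccc3OC)cc2=O)C(CC)(CC)C1=O`, gives 3.26 uM, the lowest of the three numbers; its gap to compound 1 and its gap to compound 2 are of the same size and both lie beyond the scatter, so compound 3 stands apart from the other two on this read-out. Among the compounds with values here, no two of the measured compounds differ from each other in a single place, so the data contain no isolated step that would show how a change on the phenyl group alone moves the number.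

Compound 4, `CCC1=C(O)c2c(oc(-c3cc(C)ccc3C)cc2=O)C(CC)(CC)C1=O`, has not yet been measured. It differs from compound 3 in one place: 2,5-dimethylphenyl in place of 2-methoxyphenyl on an aromatic carbon. Nothing measured here speaks directly to a swap of this kind, so the direction of the step rests on judgment rather than precedent. The step is expected to be small and toward a somewhat higher number, no more than the usual scatter would comfortably hide: a 1.5-fold higher number from compound 3 to compound 4 (0.19 log units; within the scatter). Compound 4 is therefore estimated at 5 uM in this assay, with a range from 1.5 uM to 16 uM.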

Compound 4, concentration for half-maximal effect: 3.41 uM
Estimate against measurement, compound 4: 1.5-fold (0.17 log units) above, within the range that was stated.
By their numbers in this assay, from the lowest: compounds 3 and 4 (each within the scatter of the next); then compounds 1 and 2 (each within the scatter of the next).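

In this assay, within the data shown here, the exchange of 2-methoxyphenyl for 2,5-dimethylphenyl on the aromatic carbon next to the ring oxygen comes to a 1.0-fold higher number from compound 3 to compound 4 (0.02 log units; within the scatter), and this is the first change in the set that can be read in isolation. Among these compounds, it shows that this position accepts the all-carbon 2,5-dimethylphenyl in place of 2-methoxyphenyl without a shift beyond the scatter, even though the hydrogen-bond acceptor counted on the leaving group has no counterpart on the entering group, so in this pair that acceptor is not needed to keep the number where it stands. Nothing at hand explains why the two groups read alike.

The compounds shown leave open whether the phenyl group at this position would hold its number with an amine or a carboxylic acid on it, or with a longer chain such as butoxy in place of the methoxy. They also leave open how a pyridine or a thiophene would read in place of the phenyl ring, and whether the ethyl groups of the shared core could be exchanged for propyl groups.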